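This account rests on a few compounds, and the source may have more. Where it says the series, first, only, none or still open, it means among the compounds named here.

Measured compounds:
compound 1 `Oc1ccccc1/C=N/c1nnc(SCc2nnc(-c3ccccc3)o2)s1`: 9760 nM
compound 2 `Oc1ccccc1/C=N/c1nnc(SCc2nnc(-c3ccccc3Cl)o2)s1`: 18100 nM
compound 3 `Oc1ccccc1/C=N/c1nnc(SCc2nnc(-c3ccccc3Br)o2)s1`: 9140 nM

All three share one core and differ only in the phenyl group on the five-membered ring. In a functional assay on MCF7 cells (Homo sapiens) for inhibition, read by CCK-8 assay (a lower number here means a stronger inhibitor, a higher number a weaker inhibitor), compound 3 gives the smallest of the three numbers, yet the steps of a 1.1-fold lower number from compound 1 to compound 3 (0.03 log units; within the scatter) and a 2.0-fold lower number from compound 2 to compound 3 (0.30 log units; within the scatter) lie within the scatter, so the three cannot be told apart. Compound 4 `Cc1cccc(-c2nnc(CSc3nnc(/N=C/c4ccccc4O)s3)o2)c1` is not yet measured; its change is 3-methylphenyl in place of 2-bromophenyl on an aromatic carbon. Going by the values given here, the steps that bear on it, a 1.9-fold higher number from compound 1 to compound 2 (0.27 log units; within the scatter), a 1.1-fold lower number from compound 1 to compound 3 (0.03 log units; within the scatter) and a 2.0-fold lower number from compound 2 to compound 3 (0.30 log units; within the scatter), show that altering this phenyl ring has not moved the number beyond the scatter. Among the compounds with values here, no measured step swaps a bromo for a methyl, so the expectation rests on that pattern alone. Compound 4 is therefore expected near 10000 nM, within 4000 nM to 25000 nM. The expected step of a 1.1-fold higher number from compound 3 to compound 4 (0.04 log units; within the scatter) stays within the scatter.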

Compound 4, half-maximal inhibitory concentration: 11600 nM
Estimate against measurement, compound 4: 1.2-fold (0.06 log units) below; the measured number falls inside the stated range.
By their numbers in this assay, from the lowest: compounds 3, 1, 4 and 2 (each within the scatter of the next).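

In this assay, 3-methylphenyl stays within the scatter whether it replaces 2-bromophenyl (a 1.3-fold higher number from compound 3 to compound 4 (0.10 log units; within the scatter)), 2-chlorophenyl (a 1.6-fold lower number from compound 2 to compound 4 (0.19 log units; within the scatter)) or unsubstituted phenyl (a 1.2-fold higher number from compound 1 to compound 4 (0.08 log units; within the scatter)). So a methyl group, unlike the earlier halogens, also leaves the number within the scatter, as does the move from the 2-substituted names to a 3-substituted one. No supporting data explain this flat result. Still open, on these data alone, is whether an amine or a carboxylic acid on this phenyl ring would move the number beyond the scatter.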